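A Dimethoxyphenyl Variant Expected to Stay Inactive

The source may report more compounds than this note shows. Statements on the series, on what has been measured and on what is new or still open speak of the compounds shown alone.

Compound 1 `COc1cc(-c2nnc3n2NC(CC(=O)c2ccc(C)cc2)(c2ccccc2)S3)cc(OC)c1OC` was tested in a functional assay on MCF7 cells (Homo sapiens) for cytotoxicity, read by MTT assay, with a stated time of 48 h; a lower number here means a stronger inhibitor, a higher number a weaker inhibitor; there compound 1 reached only the limit of the assay at > 200000 nM. Compound 2 `CCOC(=O)CC1(c2ccccc2)Nn2c(nnc2-c2cc(OC)c(OC)c(OC)c2)S1` likewise gave only a limit in this assay, namely > 200000 nM. The step that the two limits leave unreadable from compound 1 to compound 2 therefore cannot be read, since (the limit of > 200000 nM in this assay, at which 2 of the 2 values shown sit). Compound 3 `COc1ccc(C2(CC(=O)c3ccc(C)cc3)Nn3c(nnc3-c3cc(OC)c(OC)c(OC)c3)S2)c(OC)c1` differs from compound 1 by 2,4-dimethoxyphenyl in place of phenyl on a saturated ring carbon. Among the measured compounds shown here, no measured step bears on this change, and both known values are limits, so no shift beyond the scatter is expected. Compound 3 is expected to remain at the limit, a step of a number no higher from compound 1 to compound 3 (the limit leaves the size open). The estimate for compound 3 is 200000 nM, ranging from 60000 nM to 500000 nM.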

Compound 3, half-maximal inhibitory concentration: 10900 nM
Compound 3: middle estimate off by 18-fold (1.26 log units), on the high side; the measured number lies below the stated range.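

In this assay, the saturated ring carbon proves to be a place where a change can be read: 2,4-dimethoxyphenyl in place of phenyl gives an at least 18-fold lower number from compound 1 to compound 3 (1.26 log units; beyond the scatter). Going by these compounds, the full size of this step stays open, since the value of compound 1 is only a limit. Compound 3 is the only compound shown with a readable number, and the others stay at the limit: the limit of > 200000 nM in this assay, at which 2 of the 3 values shown sit.

On these data alone, whether 4-methoxyphenyl, with a single methoxy group, would do the same on this carbon remains open. So does whether 2,4-dimethoxyphenyl would give a readable number alongside the ethoxy group of compound 2.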